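Removing a trifluoromethyl from the urea aryl of compound 3

The source may hold more compounds than are shown below. What is called first, only, known or untested is meant among the compounds shown, and "the series" means these compounds.

The three measured compounds, all tested in a functional assay on NCI-H460 cells (Homo sapiens) for inhibition, read by sulforhodamine B assay, with a stated time of 48 h, tested at 0.01 uM; a higher number here means a weaker effect of the compound at the concentration tested, a lower number a stronger effect:
Compound 1 `O=C(Nc1cccc(-n2cc(-c3ccncc3)c(-c3cc(O)cc(Cl)c3)n2)c1)Nc1ccc(Cl)c(C(F)(F)F)c1` gives 101%.
Compound 2 `O=C(Nc1cccc(-n2cc(-c3ccncc3)c(-c3cc(O)cc(Cl)c3)n2)c1)Nc1ccc(Cl)c(Cl)c1` gives 102%.
Compound 3 `COc1cc(Cl)cc(-c2nn(-c3cccc(NC(=O)Nc4cc(C(F)(F)F)cc(C(F)(F)F)c4)c3)cc2-c2ccncc2)c1` gives 101%.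

In this assay compound 3 stands level with compound 1 at the digits printed; together they hold the lowest of the three numbers, and the gap to compound 2 is within the scatter, so no order among the three can be read from these values. All three compounds leave the cells essentially unaffected at the concentration tested.

Among the compounds with values here, the single measured step on the urea aryl, a number 1 percentage points higher from compound 1 to compound 2 (within the scatter), changes nothing beyond the scatter. Within the data shown here, it is the only step that bears on the move from compound 3 to compound 4 `COc1cc(Cl)cc(-c2nn(-c3cccc(NC(=O)Nc4cccc(C(F)(F)F)c4)c3)cc2-c2ccncc2)c1`, in which (hydrogen in place of trifluoromethyl on an aromatic carbon). Among the measured compounds shown here, that step swaps one substituent for another on the same kind of aromatic carbon, whereas here a trifluoromethyl is removed outright, so the comparison is only loose; still, nothing among the measured compounds points to a change beyond the scatter.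

Compound 4 is therefore expected at 100%, within 90% to 110%, which in this assay means an expected step of a number 1 percentage points lower from compound 3 to compound 4 (within the scatter).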

Compound 4, a percentage reported as activity, at one concentration (the size of the read-out at that concentration, not a potency): 102%
For compound 4 the middle estimate is 2 percentage points below the measured one, within the range that was stated.
By their numbers in this assay, from the lowest: compounds 1, 3, 2 and 4 (each within the scatter of the next).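

In this assay, taking a trifluoromethyl off the urea aryl and leaving hydrogen on that aromatic carbon gives a number 1 percentage points higher from compound 3 to compound 4 (within the scatter). Unlike the earlier step, which replaced one substituent with another, this change leaves the position with no substituent at all, and the read-out still does not move beyond the scatter. Compound 4 therefore joins the other three in leaving the cells essentially unaffected at the concentration tested, and no measurement shown here offers an explanation for this flat result.

The compounds shown leave open whether a different kind of group on this aromatic carbon, such as an amine, a carboxylic acid or a longer chain, would shift the read-out beyond the scatter. They also leave open whether removing the trifluoromethyl would make any difference at a concentration where these compounds have a clear effect on the cells, since a read-out this flat cannot separate them.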